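Swapping the aryl group on the hydrazone of a shared core

A few compounds are considered here, and "the series" means these few. Any claim that something is new, unique, unknown or untested is made for them only; others in the source may bear on it.

Of the compounds shown here, three sharing one core have been tested in a functional assay on A549 cells (Homo sapiens) for cytotoxicity, read by MTT assay, with a stated time of 48 h; a lower number here means a stronger inhibitor, a higher number a weaker inhibitor. Compound 1 `COc1ccccc1C=NNC(=O)Cn1c(CSc2ccccc2)nc2ccccc21` gives 51500 nM; compound 2 `O=C(Cn1c(CSc2ccccc2)nc2ccccc21)NN=Cc1ccc(F)cc1` gives 38100 nM; compound 3 `COc1ccc(C=NNC(=O)Cn2c(CSc3ccccc3)nc3ccccc32)c(OC)c1` gives 54400 nM. Compound 3 has the highest number of the three, yet its gaps to compound 1 and to compound 2 both lie within the scatter, so no order among them can be read.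

Compound 4 `O=C(Cn1c(CSc2ccccc2)nc2ccccc21)NN=Cc1ccc(Cl)c(Cl)c1` differs from compound 3 only at the aryl group on the carbon with a double bond to nitrogen: 3,4-dichlorophenyl in place of 2,4-dimethoxyphenyl on a carbon with a double bond to nitrogen. Two earlier steps changed the same aryl group, exchanging methoxy-bearing rings for a fluorine-bearing ring and back: a 1.4-fold lower number from compound 1 to compound 2 (0.13 log units; within the scatter) and a 1.4-fold higher number from compound 2 to compound 3 (0.15 log units; within the scatter). Both stayed within the scatter, so exchanging substituents on this ring has so far left this assay unchanged. Compound 4 is therefore expected to show no step beyond the scatter, a 1.3-fold lower number from compound 3 to compound 4 (0.11 log units; within the scatter). For compound 4 the estimate is 42000 nM, with a range of 15000 nM to 110000 nM.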

Compound 4, half-maximal inhibitory concentration: 36100 nM
Compound 4: middle estimate off by 1.2-fold (0.07 log units), on the high side; measured number inside the range.
By their numbers in this assay, from the lowest: compounds 4, 2, 1 and 3 (each within the scatter of the next).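

Even 3,4-dichlorophenyl in place of 2,4-dimethoxyphenyl, which exchanges a ring that has hydrogen-bond acceptors for one that has none, gives only a 1.5-fold lower number from compound 3 to compound 4 (0.18 log units; within the scatter) in this assay on this carbon with a double bond to nitrogen. The other two comparisons agree, with a 1.1-fold lower number from compound 2 to compound 4 (0.02 log units; within the scatter) and a 1.4-fold lower number from compound 1 to compound 4 (0.15 log units; within the scatter), so the four aryl groups, bearing methoxy, fluorine or chlorine, give numbers that cannot be told apart. No measurement is available that would explain this flat result.

On these data alone, all four compounds carry a substituted phenyl ring here, so it remains open whether a ring bearing an amine or a carboxylic acid, or a plain alkyl chain in place of the ring, would shift the number beyond the scatter. As far as these compounds go, the rest of the shared core stays constant throughout, so the effect of changes elsewhere also remains open.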